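The source may hold more compounds than are shown below. What is called first, only, known or untested is meant among the compounds shown, and "the series" means these compounds.

Compound 1 `CCN(CC)CCCC(C)/N=C(/N)NC(=O)c1cccc(Cl)c1CCc1cc(Br)ccc1OC` — 0.83 nM
Compound 2 `COc1ccc(Br)cc1CCc1c(F)cccc1C(=O)/N=C(\N)NCCN1CCCC1` — 190 nM
Compound 3 `CCN(CC)CCCC(C)/N=C(/N)NC(=O)c1cccc(F)c1CCc1ccccc1Cl` — 26000 nM

In an assay for binding affinity to Melanocortin receptor 4 (Homo sapiens) (a lower number here means a stronger inhibitor, a higher number a weaker inhibitor), compound 2 gives 190 nM, the second highest of the three numbers. Compound 1 gives the lowest number with 0.83 nM, while compound 3 gives the highest with 26000 nM. Compound 4 `COc1ccc(Br)cc1CCc1c(F)cccc1C(=O)/N=C(\N)NCC(C)C` differs from compound 2 in one place: isopropyl in place of (pyrrolidin-1-yl)methyl on a saturated chain carbon bound to an amine nitrogen. For the measured compounds named here, no measured pair shows this change, and every measured compound carries an amine-bearing chain on the guanidine, so the numbers give no direct guidance. The change removes the only hydrogen-bond acceptor of that chain, and the number for compound 4 is expected to rise beyond the scatter, by a step of a 6.3-fold higher number from compound 2 to compound 4 (0.80 log units; beyond the scatter) from compound 2. Compound 4 is estimated at 1200 nM, within 250 nM to 6000 nM.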

Compound 4, inhibition constant: 770 nM
For compound 4 the middle estimate is 1.6-fold (0.19 log units) above the measured one; the range from low to high includes it.
By their numbers in this assay, from the lowest: compound 1; then compound 2; then compound 4; then compound 3.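

In this assay, for the compounds shown here, isopropyl in place of (pyrrolidin-1-yl)methyl on a saturated chain carbon bound to an amine nitrogen gives a 4.1-fold higher number from compound 2 to compound 4 (0.61 log units; beyond the scatter), the first direct reading of this position. The step is modest, and compound 4, whose chain carries no ring and no hydrogen-bond acceptor, still gives 770 nM, so the amine-bearing chain is not needed for a measurable number. Nothing at hand accounts for the step. As far as these compounds go, it stays open whether the ring or the nitrogen matters, which a cyclopentyl group or a dimethylamino group at this place would separate.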